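Ester variation on the shared core: isopropyl to benzyl

This account rests on a few compounds, and the source may have more. Where it says the series, first, only, none or still open, it means among the compounds named here.

Within the data shown here, compound 2 `CCOC(=O)C1=C(C)NC(C)=C(C(=O)OC(C)C)C1c1cnc(SC)n1Nc1ccccc1` is one of two compounds measured in an assay on isolated protein (strain albino) for antagonist activity at Voltage-dependent L-type calcium channel subunit alpha-1C (Cavia porcellus); a lower number here means a stronger inhibitor, a higher number a weaker inhibitor; compound 2 gives 3.22 nM, the higher end of the two numbers, by a gap within the scatter. Compound 1 `CCOC(=O)C1=C(C)NC(C)=C(C(=O)OCC)C1c1cnc(SC)n1Nc1ccccc1` gives 1.69 nM; the step of a 1.9-fold higher number from compound 1 to compound 2 (0.28 log units; within the scatter) is the only one measured at this position. Compound 3 `CCOC(=O)C1=C(C)NC(C)=C(C(=O)OCc2ccccc2)C1c1cnc(SC)n1Nc1ccccc1` differs from compound 2 by benzyl in place of isopropyl on an oxygen next to a carbonyl group. Among the measured compounds shown here, the single step seen at this ester position was small, so only a step within the scatter is expected, a 1.1-fold higher number from compound 2 to compound 3 (0.04 log units; within the scatter). Compound 3 is estimated at 3.5 nM, within a range of 1.2 nM to 11 nM.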

Compound 3, half-maximal inhibitory concentration: 1.86 nM
Beside the measured number, compound 3's estimate is 1.9-fold (0.27 log units) above it; the measured number falls inside the stated range.
By their numbers in this assay, from the lowest: compounds 1, 3 and 2 (each within the scatter of the next).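

Benzyl on the oxygen next to a carbonyl group brings a six-membered aromatic ring into this ester position, and this assay still gives a 1.7-fold lower number from compound 2 to compound 3 (0.24 log units; within the scatter) and a 1.1-fold higher number from compound 1 to compound 3 (0.04 log units; within the scatter) in the two steps that reach it. Compounds 1, 2 and 3 therefore lie within the scatter of one another, so this position accepts an aromatic ring as well as the open-chain groups. Nothing available here says why the position stays this flat.

As far as these compounds go, whether a carboxylic acid or an aminoethyl ester would sit at the same level remains open. So does whether the other ethyl ester on the shared core accepts benzyl in the same way.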